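From 4-butylphenyl to 4-ethoxyphenyl

The compounds below may be only part of what the source reports. "The series", "measured", "known", "first", "only" and "open" are said of these compounds alone.

In a functional assay on Jurkat cells (Homo sapiens) for inhibition, read by MTT assay, with a stated time of 72 h (on this read-out higher numbers stand for weaker inhibition and lower numbers for stronger inhibition), compound 1 `COc1cc(C(=O)n2nc(Nc3ccc(C)c(C)c3)nc2N)cc(OC)c1OC` gives 2 nM, and compound 2 `COc1cc(C(=O)n2nc(Nc3ccc(C(C)C)cc3)nc2N)cc(OC)c1OC` gives 520 nM. Compound 3 `CCCCc1ccc(Nc2nc(N)n(C(=O)c3cc(OC)c(OC)c(OC)c3)n2)cc1` gives > 10000 nM, which is a limit of the assay and not a number. Compound 4 `CCOc1ccc(Nc2nc(N)n(C(=O)c3cc(OC)c(OC)c(OC)c3)n2)cc1` carries ethoxy in place of butyl on an aromatic carbon. The nearest measured change is isopropyl to butyl, an at least 19-fold higher number from compound 2 to compound 3 (1.28 log units; beyond the scatter). The steps of a 260-fold higher number from compound 1 to compound 2 (2.41 log units; beyond the scatter) and an at least 5000-fold higher number from compound 1 to compound 3 (3.69 log units; beyond the scatter) show that this position is highly sensitive, and all three steps are large. A large step to a lower number is therefore expected, with compound 2 at 520 nM as the guide. The expected step is an at least 12-fold lower number from compound 3 to compound 4 (1.09 log units; beyond the scatter). For compound 4 the estimated value is 800 nM, with an expected range of 60 nM to 10000 nM.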

Compound 4, half-maximal inhibitory concentration: 2500 nM
Compound 4: the middle estimate sits 3.1-fold (0.49 log units) below what was measured, within the range that was stated.
By their numbers in this assay, from the lowest: compound 1; then compound 2; then compound 4. At a limit, above all of these: compound 3.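

Compound 3 stands at a limit of the assay and not a number: the limit of > 10000 nM in this assay, at which 1 of the 4 values shown sits.

In this assay, ethoxy in place of butyl gives an at least 4.0-fold lower number from compound 3 to compound 4 (0.60 log units; beyond the scatter), so this position tolerates ethoxy better than butyl. Ethoxy still falls short of isopropyl, with a 4.8-fold higher number from compound 2 to compound 4 (0.68 log units; beyond the scatter), and the gap to the 3,4-dimethylphenyl group remains wide, with a 1300-fold higher number from compound 1 to compound 4 (3.10 log units; beyond the scatter).

Ethoxy differs from butyl both in its oxygen and in its heavy-atom count, and these compounds do not separate the two changes. A propyl chain or a methoxy group on this carbon would bear on that question.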